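Swapping the Heterocycle on an Aryl Urea Acyltransferase Inhibitor

A few compounds are considered here, and "the series" means these few. Any claim that something is new, unique, unknown or untested is made for them only; others in the source may bear on it.

This account follows compound 1, `Cc1cc(C)c(NC(=O)N(Cc2ccc(-c3n[nH]c(C)n3)cc2)C2CCCCCC2)c(C)c1`, as it is measured in an assay on microsomes from intestine for inhibition of acyl-CoA:cholesterol acyltransferase (Oryctolagus cuniculus) (on this read-out higher numbers stand for weaker inhibition and lower numbers for stronger inhibition), where compound 1 gives 120 nM. Among the two numbers recorded so far, compound 1 stands at the highest. Among the compounds with values here, the only other measured compound is compound 2, `O=C(Nc1c(F)cc(F)cc1F)N(Cc1cccc(-c2cc[nH]n2)c1)C1CCCCCC1`, and in this assay compound 2 gives 22 nM, a number lower than that of compound 1 by a margin that lies beyond the usual scatter. Compound 2 differs from compound 1 in more than one place, so its values show only what each compound does on its own.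

The step of interest leads to compound 3, `Cc1cc(C)c(NC(=O)N(Cc2ccc(-c3ccn(C)n3)cc2)C2CCCCCC2)c(C)c1`, which has not yet been measured. It is obtained from compound 1 by the change (1-methyl-1H-pyrazol-3-yl in place of 5-methyl-1H-1,2,4-triazol-3-yl on an aromatic carbon). Within the data shown here, there is no measured pair in these data that isolates this kind of change, so any expectation rests on the single anchor provided by compound 1. The author expects the step from compound 1 to compound 3 to be small, a 1.3-fold higher number from compound 1 to compound 3 (0.10 log units; within the scatter), most likely within the scatter or at most a modest move toward a weaker number. Compound 3 is therefore estimated at 150 nM, with a range from 50 nM to 450 nM.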

Compound 3, half-maximal inhibitory concentration: 44 nM
Compound 3: middle estimate off by 3.4-fold (0.53 log units), on the high side; measured number outside the range, below it.
By their numbers in this assay, from the lowest: compounds 2 and 3 (each within the scatter of the next); then compound 1.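

In this assay, within the data shown here, putting 1-methyl-1H-pyrazol-3-yl in place of 5-methyl-1H-1,2,4-triazol-3-yl on the aromatic carbon para to a large group gives a 2.7-fold lower number from compound 1 to compound 3 (0.44 log units; beyond the scatter), the first step here that isolates a change at this position. It shows that this position responds to the identity of the five-membered aromatic ring, and that a ring with no hydrogen-bond donor can stand here without a loss of inhibition, even though the heavy-atom count and the hydrogen-bond acceptor count stay the same. The step changes the number of ring hetero atoms, the hydrogen-bond donor and the seat of the methyl group together, and nothing available explains why the number falls.

The compounds shown leave open which of these differences carries the step, since neither an unmethylated 1H-pyrazol-3-yl nor a 1-methyl-1H-1,2,4-triazol-3-yl appears at this position on the shared core. They also leave open how far the position extends beyond five-membered rings with ring nitrogens, for instance to a pyridine ring, a carboxylic acid or an amine.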